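The source may report more compounds than this note shows. Statements on the series, on what has been measured and on what is new or still open speak of the compounds shown alone.

Going by the values given here, compound 2 `C[C@]1(CN2CCc3nc(-c4cc(F)ccc4F)ccc3C2)Cn2cc([N+](=O)[O-])nc2O1` is the only one of the pair with a number in hand, and that number comes from an ADME assay on Vero cells (Chlorocebus sabaeus) for cytotoxicity, read by MTT assay, with a stated time of 72 h; a higher number here means that more compound is tolerated, a lower number that less compound is tolerated. In this assay compound 2 gives > 32 ug/mL, which is a limit of the assay rather than a measured value, and it sits at the limit of > 32 ug/mL in this assay, at which 1 of the 2 values shown sits. Compound 1 `C[C@]1(CN2CCc3nc(-c4ccc(Cl)cc4)ccc3C2)Cn2cc([N+](=O)[O-])nc2O1` has "not determined" (no result reported) in this assay, so nothing can be compared between the two. Compound 3 `C[C@]1(CN2CCc3nc(-c4cccc(Cl)c4F)ccc3C2)Cn2cc([N+](=O)[O-])nc2O1` differs from compound 2 in one place: 3-chloro-2-fluorophenyl in place of 2,5-difluorophenyl on an aromatic carbon. Among the compounds with values here, no measured step between compounds exists here, so the size of this change cannot be read from data; the expectation is that a number no higher from compound 2 to compound 3 (the limit leaves the size open) stays within the scatter, with no direction to it. Compound 3 is therefore expected to give 32 ug/mL in this assay, within a range from 16 ug/mL to 64 ug/mL, and most likely again as a limit rather than a number.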

Compound 3, half-maximal cytotoxic concentration: > 32 ug/mL
Compound 3 ended at the assay's limit (the forecaster's own chance of this, stated with the estimate: 80%); the middle value lies on the limit itself.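

In this assay compound 2 and compound 3 both end at a limit rather than a number, so no step between them can be read: the limit of > 32 ug/mL in this assay, at which 2 of the 3 values shown sit.

The compounds shown leave open where the actual half-maximal cytotoxic concentration of either compound lies, and whether 3-chloro-2-fluorophenyl in place of 2,5-difluorophenyl shifts it.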